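Methoxyphenyl to methoxypyrimidinyl on the thiazole-bearing series

The source may report more compounds than this note shows. Statements on the series, on what has been measured and on what is new or still open speak of the compounds shown alone.

Measured so far:
compound 1 `CC[C@@H]1CN(c2scnc2-c2nc3ccccc3[nH]2)CCN1C(=O)Cn1cnc2cccnc21` — 851 nM
compound 2 `COc1ccc(-c2nc(C(F)(F)F)sc2N2CCN(C(=O)Cn3cnc4cccnc43)[C@H](C)C2)cc1` — 1190 nM

In an assay on blood for inhibition of C-X-C chemokine receptor type 3 (Homo sapiens), with a stated time of 30 min (a higher number here means a weaker inhibitor, a lower number a stronger inhibitor), compound 2 gives 1190 nM, the higher of the two numbers, while compound 1 gives 851 nM; the two lie within the scatter of each other, so no order between them is claimed.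

Compound 3 `COc1ncc(-c2nc(C(F)(F)F)sc2N2CCN(C(=O)Cn3cnc4cccnc43)[C@H](C)C2)cn1` differs from compound 2 by 2-methoxypyrimidin-5-yl in place of 4-methoxyphenyl on an aromatic carbon. Within the data shown here, no measured pair shows this change, so the step is expected to be small, if anything toward a weaker inhibitor, and is estimated as a 1.3-fold higher number from compound 2 to compound 3 (0.13 log units; within the scatter). For compound 3 the expected value in this assay is 1600 nM, with a range of 600 nM to 4500 nM.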

Compound 3, half-maximal inhibitory concentration: 158 nM
Compound 3: the middle estimate sits 10-fold (1.01 log units) above what was measured, outside the stated range (below it).
By their numbers in this assay, from the lowest: compound 3; then compounds 1 and 2 (each within the scatter of the next).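

In this assay the group on this aromatic carbon of the five-membered ring clearly matters: 2-methoxypyrimidin-5-yl in place of 4-methoxyphenyl gives a 7.5-fold lower number from compound 2 to compound 3 (0.88 log units; beyond the scatter), with the heavy-atom count unchanged and carbon giving way to nitrogen in the six-membered ring. The earlier compounds shown here offered no pair that tested this position. Nothing available explains the size of this step. Open, from the compounds shown here alone, is whether the step holds with an amine in place of the methoxy on the pyrimidine, and whether it carries over to the core of compound 1.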